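The source may hold more compounds than are shown below. What is called first, only, known or untested is meant among the compounds shown, and "the series" means these compounds.

Compound 1 `Cc1cc(NCc2cc(Cl)cc(Cl)c2)nc(N)n1` was tested in an assay on cells for inhibition of S-adenosylmethionine decarboxylase proenzyme (Homo sapiens), read by mass spectrometry, at pH 7.2; a lower number here means a stronger inhibitor, a higher number a weaker inhibitor. For compound 1 the result is only a limit, > 180000 nM. Compound 2 `COc1ccc(-c2cc(Cl)cc(Nc3cc(C)nc(N)n3)c2)cc1` likewise returns only a limit in this assay, namely > 180000 nM. Compound 2 therefore stands at no number at all, since both values shown rest at the limit of > 180000 nM in this assay, at which 2 of the 2 values shown sit. Compound 3 `Cc1cc(Nc2cc(Cl)cc(-c3ccc(C#N)cc3)c2)nc(N)n1` differs from compound 2 by cyano in place of methoxy on an aromatic carbon. No measured step of this kind exists among the compounds shown, so no direction can be drawn from them. Compound 3 is expected to stay near the limit in this assay, with an estimate of 200000 nM, between 50000 nM and 1000000 nM. The expected step that the limit leaves unreadable from compound 2 to compound 3 is none beyond the scatter.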

Compound 3, half-maximal inhibitory concentration: > 7000 nM
Compound 3 was reported as a limit (the forecaster's own chance of this, stated with the estimate: 85%); the middle value is on the limit's open side.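

Compound 2 and compound 3 both rest at limits in this assay, so no step can be read between them. Whether cyano in place of methoxy changes inhibition at all remains open, as does what any of these compounds would give as an actual number.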